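A few compounds are considered here, and "the series" means these few. Any claim that something is new, unique, unknown or untested is made for them only; others in the source may bear on it.

Measured compounds:
compound 1: `CNC(=O)c1cc(Oc2ccc(NC(=O)c3cc4cccnc4n(-c4ccc(F)cc4)c3=O)cc2)ccn1`; 210 nM
compound 2: `CNC(=O)c1cc(Oc2ccc(NC(=O)c3cc4cccnc4n(-c4ccc(C(F)(F)F)cc4Cl)c3=O)cc2)ccn1`; 2110 nM

Both numbers come from a functional assay on NCI-H460 cells (Homo sapiens) for antiproliferative activity, read by MTT assay, with a stated time of 72 h; on this read-out higher numbers stand for weaker inhibition and lower numbers for stronger inhibition. Among the measured compounds shown here, compound 1 stands as the lower of the two numbers; the only measured step is a 10-fold higher number from compound 1 to compound 2 (1.00 log units; beyond the scatter), which concerns the aryl group on the aromatic nitrogen and leaves the rest of the shared core untouched.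

Compound 3 is `CCCNC(=O)c1cc(Oc2ccc(NC(=O)c3cc4cccnc4n(-c4ccc(F)cc4)c3=O)cc2)ccn1`. It differs from compound 1 by ethyl in place of hydrogen on a saturated chain carbon bound to an amide-type nitrogen. For the measured compounds named here, no measured step touches this part of the molecule: the step from compound 1 to compound 2 changes a different position, so it gives no direct reading for this change. Going by the values given here, what is known is only that compound 1 itself gives 210 nM in this assay.

Among the compounds with values here, with no step to lean on, the expectation is that compound 3 stays close to compound 1, the step of a 1.3-fold higher number from compound 1 to compound 3 (0.12 log units; within the scatter) being within or just at the edge of the usual scatter. Compound 3 is accordingly estimated at 280 nM, with a range from 90 nM to 900 nM.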

Compound 3, half-maximal inhibitory concentration: 120 nM
Estimate against measurement, compound 3: 2.3-fold (0.37 log units) above; low and high end bracket the measured number.
By their numbers in this assay, from the lowest: compounds 3 and 1 (each within the scatter of the next); then compound 2.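

In this assay, among the compounds shown here, extending the amide substituent from methylcarbamoyl to propylcarbamoyl gives the first reading at this position (a 1.8-fold lower number from compound 1 to compound 3 (0.24 log units; within the scatter)), so compound 1 and compound 3 cannot be told apart on this read-out. Ethyl in place of hydrogen on the saturated chain carbon bound to the amide-type nitrogen therefore leaves the number within the scatter, whereas the change on the aromatic nitrogen (a 10-fold higher number from compound 1 to compound 2 (1.00 log units; beyond the scatter)) lies beyond it. No measurement in the series bears on why the propyl chain leaves the value in this range, and this single pair gives no trend with chain length.

Still open, as far as these compounds go, is whether the position stays this permissive with a longer chain such as butyl or hexyl, with a branched or ring-bearing group such as isopropyl or cyclopropyl, or with a chain ending in an amine or a carboxylic acid. Also open, from the compounds shown here alone, is whether the propylcarbamoyl group would give a similar reading when combined with the 2-chloro-4-(trifluoromethyl)phenyl group of compound 2, since the two changes are seen only separately here.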